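Swapping fluoro for bromo on a weak inhibitor

The source may report more compounds than this note shows. Statements on the series, on what has been measured and on what is new or still open speak of the compounds shown alone.

Compound 1 `O=c1c([C@@H]2C[C@H](c3ccccc3)ON2c2ccccc2)coc2ccc(F)cc12` is the weaker of the two measured compounds: in a functional assay on A549 cells (Homo sapiens) for inhibition, read by sulforhodamine B assay, with a stated time of 48 h (on this read-out higher numbers stand for weaker inhibition and lower numbers for stronger inhibition), compound 1 gives 51500 nM, whereas compound 2 `COC(=O)[C@@]1(C)C[C@@H](c2coc3ccc(C)cc3c2=O)N(c2ccccc2)O1`, built on a different core, gives 700 nM in this assay, a gap beyond the scatter. Compound 3 `O=c1c([C@@H]2C[C@H](c3ccccc3)ON2c2ccccc2)coc2ccc(Br)cc12` differs from compound 1 by one change: bromo in place of fluoro on an aromatic carbon. For the measured compounds named here, no measured pair shows this exchange, so the step is expected to be small, if anything toward stronger inhibition, and may not exceed the scatter. Compound 3 is estimated at 30000 nM in this assay, within 8000 nM to 120000 nM, the expected step being a 1.7-fold lower number from compound 1 to compound 3 (0.23 log units; within the scatter).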

Compound 3, half-maximal inhibitory concentration: 51000 nM
The estimate for compound 3 lay 1.7-fold (0.23 log units) below the measured number, and the stated range covers the measured number.
By their numbers in this assay, from the lowest: compound 2; then compounds 3 and 1 (each within the scatter of the next).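

In this assay, for the compounds shown here, the exchange of fluoro for bromo on this aromatic carbon gives a 1.0-fold lower number from compound 1 to compound 3 (0.00 log units; within the scatter) and so leaves the read-out unmoved, which the earlier compounds could not show, since neither formed a pair differing at this place. On the core of compound 1, the two halogens read alike here. Nothing available bears on why this is so. Open, from the compounds shown here alone, is whether a group of another kind on the same carbon, such as an amine or a carboxylic acid, would shift the number. Two halogens alone cannot say how far this position responds to change.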